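Shortening the Side Chain of Compound 2

The compounds below may be only part of what the source reports. "The series", "measured", "known", "first", "only" and "open" are said of these compounds alone.

Compound 1 `CN(C)CCCn1c(=O)n(C2OC(CO)[C@@H](O)[C@H]2O)c2nc(N)nc(O)c21` and compound 2 `CCCCCCn1c(=O)n(C2OC(CO)[C@@H](O)[C@H]2O)c2nc(N)nc(O)c21` share a core and differ only in the chain on the aromatic nitrogen. In a functional assay on the whole organism with Mus musculus as the target (on this read-out lower numbers stand for smaller maximal responses and higher numbers for larger maximal responses), compound 1 gives 63%, while compound 2 gives 11%, the lower of the two numbers; the step of a number 52 percentage points lower from compound 1 to compound 2 (beyond the scatter) lies beyond the scatter. Compound 3 `CCCCn1c(=O)n(C2OC(CO)[C@@H](O)[C@H]2O)c2nc(N)nc(O)c21` is the next compound in this series; its change from compound 2 is hydrogen in place of ethyl on a saturated chain carbon, four bonds along the chain from an aromatic nitrogen. For the measured compounds named here, the only measured step concerns a different replacement, dimethylamino to propyl, and says nothing directly about cutting the chain shorter, so no measured step bears closely on this change. Compound 2 already stands low, and with no shown evidence of a direction, a small step of a number 9 percentage points higher from compound 2 to compound 3 (within the scatter) is expected. Compound 3 is therefore estimated at 20%, within a range from 5% to 45%.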

Compound 3, largest response reached (reported as maximal response), in percent of the reference or control that the assay uses: 70%
Compound 3: middle estimate off by 50 percentage points, on the low side; the whole stated range lies below it.
By their numbers in this assay, from the lowest: compound 2; then compounds 1 and 3 (each within the scatter of the next).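

In this assay, hydrogen in place of ethyl on a saturated chain carbon, four bonds along the chain from an aromatic nitrogen, gives a number 59 percentage points higher from compound 2 to compound 3 (beyond the scatter), so the response at this position depends strongly on the chain itself. The low number of compound 2 therefore cannot be read as the simple loss of dimethylamino: compound 3 also lacks that group, and the step to it reads a number 7 percentage points higher from compound 1 to compound 3 (within the scatter). Nothing shown gives a reason for the large effect of this chain change.

The compounds shown leave open whether the response falls gradually or abruptly as the chain grows from butyl to hexyl, and a pentyl chain would address that. They also leave open whether a shorter chain such as propyl, or a hydroxyl group at the chain end, would keep the response of compound 3.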